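A few compounds are considered here, and "the series" means these few. Any claim that something is new, unique, unknown or untested is made for them only; others in the source may bear on it.

Three sulfonamides have so far been tested in an assay on isolated protein for inhibition of malate dehydrogenase, mitochondrial (Sus scrofa), with stated times of 45 min and 30 min; a higher number here means a weaker inhibitor, a lower number a stronger inhibitor. Compound 1 `COc1ccc(Cl)cc1S(=O)(=O)Nc1ccc(-c2nc3ccccc3o2)cc1` gives > 63000 nM, a limit of the assay rather than a number. Compound 2 `O=S(=O)(Nc1ccc2oc(-c3ccccc3)nc2c1)c1cccs1` gives > 63000 nM, again only a limit. Compound 3 `O=S(=O)(Nc1ccc(-c2nc3ccccc3o2)cc1)c1ccc(C(F)(F)F)cc1` gives > 63000 nM, also a limit. Compound 2 therefore stands where every value shown stands, at the limit of > 63000 nM in this assay, at which 3 of the 3 values shown sit. The next compound, compound 4 `COc1ccc(S(=O)(=O)Nc2ccc3oc(-c4ccccc4)nc3c2)cc1`, keeps the core of compound 2 and alters one place: 4-methoxyphenyl in place of thiophen-2-yl on a sulfonyl sulfur. With all three measured compounds at the limit, nothing yet separates one sulfonyl substituent from another, and no step beyond the scatter is expected in this assay. This exchange is expected to amount to a step that the limit leaves unreadable from compound 2 to compound 4. Compound 4 is estimated at 100000 nM, within a range from 30000 nM to 300000 nM.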

Compound 4, half-maximal inhibitory concentration: > 63000 nM
Compound 4: a limit, no number; the forecaster's own chance of this, stated with the estimate: 85%; the middle value lies beyond the limit too.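

Going by these compounds alone, compound 2 and compound 4 each give only a limit of the assay and not a number, so no step between them can be read. The compounds shown leave open whether any change in structure would bring a measurable value in this assay.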